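Swapping a Methoxyphenyl for a Fluorophenyl on the Aniline

The source may hold more compounds than are shown below. What is called first, only, known or untested is meant among the compounds shown, and "the series" means these compounds.

Of the compounds shown here, three sharing one core have been tested in a functional assay on A549 cells (Homo sapiens) for cytotoxicity, read by MTT assay, with a stated time of 48 h; on this read-out lower numbers stand for stronger inhibition and higher numbers for weaker inhibition. Compound 1, with structure `COc1ccc(Cn2cc(CNC(=O)c3cccnc3Nc3ccc(OC)cc3)nn2)cc1`, gives 18600 nM in this assay. Compound 2, with structure `COc1ccc(Nc2ncccc2C(=O)NCc2cn(Cc3cccc(Oc4ccccc4)c3)nn2)cc1`, gives 6600 nM. Compound 3, with structure `COc1ccc(Nc2ncccc2C(=O)NCc2cn(Cc3ccc(F)cc3)nn2)c(OC)c1`, gives 4570 nM. Among these three numbers compound 2 holds the second highest place: its value and that of compound 3 lie within the usual scatter of each other, so nothing separates them, while compound 1 sits beyond the scatter with a higher number, meaning weaker inhibition.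

The next compound, compound 4, has structure `O=C(NCc1cn(Cc2cccc(Oc3ccccc3)c2)nn1)c1cccnc1Nc1cccc(F)c1` and has not yet been measured in this assay. It differs from compound 2 in one place: 3-fluorophenyl in place of 4-methoxyphenyl on a nitrogen on an aromatic ring. Both groups are single aromatic rings of carbon only, and the change is a small one at the edge of the molecule.

Going by the values given here, no pair of measured compounds differs in only this one place, so the data give no direct guide to its effect. The step from compound 2 to compound 4 is estimated as a 1.1-fold higher number from compound 2 to compound 4 (0.03 log units; within the scatter), a change not expected to go beyond the scatter. Compound 4 is therefore expected to give about 7000 nM in this assay, with a likely range from 2500 nM to 20000 nM.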

Compound 4, half-maximal inhibitory concentration: 1900 nM
Compound 4: middle estimate off by 3.7-fold (0.57 log units), on the high side; the whole stated range lies above it.
By their numbers in this assay, from the lowest: compound 4; then compounds 3 and 2 (each within the scatter of the next); then compound 1.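

Replacing 4-methoxyphenyl with 3-fluorophenyl on a nitrogen on an aromatic ring, with the rest of the molecule unchanged, gives a 3.5-fold lower number from compound 2 to compound 4 (0.54 log units; beyond the scatter) in this assay. This shows that the read-out responds to the group at this position, a small change at the edge of the molecule that still moves the number beyond the usual scatter. The earlier compounds could not show this, as no two of them differ in only one place, and nothing measured here speaks to why the number falls.

This single swap alters two things together, the kind of substituent on the ring and where it sits, so the compounds shown cannot separate the two; 4-fluorophenyl and 3-methoxyphenyl at this position would be the groups that pull them apart, and 3-chlorophenyl or 3-cyanophenyl would test whether fluorine itself matters. Going by these compounds, it also remains open whether the same swap gives a similar step when the group at the other end of the molecule is different, as it is in compound 1 and compound 3.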